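Replacing the imidazole side chain: compound 2 to compound 3

The source may hold more compounds than are shown below. What is called first, only, known or untested is meant among the compounds shown, and "the series" means these compounds.

Of the compounds shown here, two sharing one core have numbers so far in an ADME assay on liver for metabolic stability, with Liver microsome (Rattus norvegicus) as the target, using microsomes and NADPH, with a stated time of 30 min, tested at 0.5 uM; a higher number here means faster removal of the compound, a lower number slower removal. Compound 1 `CN1CCN(CCOc2nn(-c3ccccc3F)c3ccc(F)cc23)C1=O` gives 7200 mL/min/kg. Compound 2 `Fc1ccc2c(c1)c(OCCn1ccnc1)nn2-c1ccccc1F` gives 1150 mL/min/kg, the lower of the two numbers. Going by the values given here, the one measured step is a 6.3-fold lower number from compound 1 to compound 2 (0.80 log units; beyond the scatter). It puts 1H-imidazol-1-yl in place of 3-methyl-2-oxoimidazolidin-1-yl on a saturated chain carbon, two bonds along the chain from an oxygen on an aromatic ring.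

Compound 3 `O=C(COc1nn(-c2ccccc2F)c2ccc(F)cc12)N1CCOCC1` is not yet measured. It carries (morpholin-4-yl)carbonyl in place of (1H-imidazol-1-yl)methyl on a saturated chain carbon bound to an oxygen on an aromatic ring. Among the compounds with values here, no measured step covers this exact change. The step to compound 2 bears on it only indirectly, since compound 3 also gives up the five-membered aromatic ring and has a non-aromatic ring with a carbonyl, as compound 1 does. A rise is therefore expected, smaller than a 6.3-fold lower number from compound 1 to compound 2 (0.80 log units; beyond the scatter), though one step is a thin guide. The expected change is a 2.4-fold higher number from compound 2 to compound 3 (0.39 log units; beyond the scatter). For compound 3 the estimate is 2800 mL/min/kg, with an expected range of 1100 mL/min/kg to 7000 mL/min/kg.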

Compound 3, clearance: 183 mL/min/kg
Compound 3: middle estimate off by 15-fold (1.18 log units), on the high side; the measured number lies below the stated range.
By their numbers in this assay, from the lowest: compound 3; then compound 2; then compound 1.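

In this assay, an aromatic ring in the side chain proves unnecessary for a low number at this place, on a saturated chain carbon bound to an oxygen on an aromatic ring: (morpholin-4-yl)carbonyl, with its six-membered non-aromatic ring, gives a 6.3-fold lower number from compound 2 to compound 3 (0.80 log units; beyond the scatter). The same group set against (3-methyl-2-oxoimidazolidin-1-yl)methyl gives a 39-fold lower number from compound 1 to compound 3 (1.59 log units; beyond the scatter), so two groups that each hold a non-aromatic ring and a carbonyl mark the two ends of the three numbers, and these two features together do not fix the number here. Nothing at hand accounts for the difference between these groups.

Still open, as far as these compounds go, is whether the carbonyl or the morpholine ring goes with the lower number, as the two enter together: a 2-(morpholin-4-yl)ethyl group, a dimethylamide or a piperidine amide on the same chain would separate them. Also open, from the compounds shown here alone, is whether the order of the three side chains holds when the shared core, identical in all three compounds, carries other groups.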